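This account rests on a few compounds, and the source may have more. Where it says the series, first, only, none or still open, it means among the compounds named here.

Measured in a functional assay (aorta) with Oryctolagus cuniculus as the target; on this read-out higher numbers stand for weaker binding and lower numbers for tighter binding:
compound 1 `CCCCc1nc2cccnc2n1Cc1cc(Cl)c(O)c(Cl)c1`: 63.1 nM
compound 2 `CCc1nc2c(C)ccnc2n1Cc1ccc(-c2ccccc2C(=O)O)cc1`: 1.26 nM

Compound 2, at 1.26 nM, holds the lower of the two numbers, and the gap to compound 1 lies beyond the scatter. The two compounds differ in more than one place, so that gap isolates no single change. Compound 3 `CSc1nc2c(C)ccnc2n1Cc1ccc(-c2ccccc2C(=O)O)cc1` has methylsulfanyl in place of ethyl on an aromatic carbon. Among the measured compounds shown here, no measured pair tests this change. In this assay, no step beyond the scatter is expected, with a slight lean towards a higher number: the estimate is a 1.7-fold higher number from compound 2 to compound 3 (0.24 log units; within the scatter). Compound 3 is estimated at 2.2 nM, with an expected range of 0.6 nM to 8 nM.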

Compound 3, dissociation constant: 10 nM
For compound 3 the middle estimate is 4.5-fold (0.66 log units) below the measured one, and the stated range ends below it.
By their numbers in this assay, from the lowest: compound 2; then compound 3; then compound 1.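

In this assay, the carbon between two ring nitrogen atoms does not accept this exchange neutrally: methylsulfanyl in place of ethyl gives a 7.9-fold higher number from compound 2 to compound 3 (0.90 log units; beyond the scatter) beyond the scatter. Both groups have 2 heavy atoms, so matching that count at this position does not keep the number in this pair. Nothing measured here accounts for the step. Open, going by these compounds, is how a methoxy group or an amine would read at this position, and whether the step holds on a core other than that of compound 2.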